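The compounds below may be only part of what the source reports. "The series", "measured", "known", "first", "only" and "open" are said of these compounds alone.

Compound 1 `COc1cc(OC)c(-c2coc3cc(OCC=C(C)C)ccc3c2=O)cc1OC` carries a 2-methylprop-1-en-1-yl group on a saturated chain carbon bound to an oxygen on an aromatic ring, and in a functional assay on HUVEC cells (Homo sapiens) for antiproliferative activity, read by MTT assay, with a stated time of 24 h (a lower number here means a stronger inhibitor, a higher number a weaker inhibitor), compound 1 gives 3800 nM. Compound 2 `COc1cc(OC)c(-c2coc3cc(OCc4ccc(F)cc4)ccc3c2=O)cc1OC` puts a 4-fluorophenyl group in that place, and in this assay compound 2 reaches only the limit > 10000 nM, not a measured number. Compound 3 `COc1cc(OC)c(-c2coc3cc(OCc4ccccc4C(F)(F)F)ccc3c2=O)cc1OC` puts a 2-(trifluoromethyl)phenyl group there, and in this assay compound 3 likewise stands at the limit > 10000 nM, so its position is known only as a limit. The steps of an at least 2.6-fold higher number from compound 1 to compound 2 (0.42 log units; beyond the scatter) and an at least 2.6-fold higher number from compound 1 to compound 3 (0.42 log units; beyond the scatter) both show a weakening, while the step that the two limits leave unreadable from compound 2 to compound 3 cannot be read because the limit of > 10000 nM in this assay, at which 2 of the 3 values shown sit, caps both values.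

Compound 4 `COc1cc(OC)c(-c2coc3cc(OCc4ccc(C(F)(F)F)cc4)ccc3c2=O)cc1OC` is the unmeasured partner of compound 3: 4-(trifluoromethyl)phenyl in place of 2-(trifluoromethyl)phenyl on a saturated chain carbon bound to an oxygen on an aromatic ring. Of the measured steps, an at least 2.6-fold higher number from compound 1 to compound 3 (0.42 log units; beyond the scatter) bears on it most directly, and the unreadable step that the two limits leave unreadable from compound 2 to compound 3 shows that exchanging one aryl group for another in the same place produced no visible change. No step beyond the scatter is therefore expected, and the expected step is a step that the limit leaves unreadable from compound 3 to compound 4. Compound 4 is estimated at 15000 nM in this assay, within 6000 nM to 40000 nM, and most likely reported again only as a limit.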

Compound 4, half-maximal inhibitory concentration: > 10000 nM
Compound 4: no number, only a limit (the forecaster's own chance of this, stated with the estimate: 75%); the middle value is on the limit's open side.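

Replacing 2-(trifluoromethyl)phenyl with 4-(trifluoromethyl)phenyl on the saturated chain carbon bound to an oxygen on an aromatic ring gives a third aryl compound that is weaker than the compound with the 2-methylprop-1-en-1-yl group, with an at least 2.6-fold higher number from compound 1 to compound 4 (0.42 log units; beyond the scatter) in this assay. Among the compounds shown, changing where the trifluoromethyl group stands, or having trifluoromethyl in place of fluoro on an aromatic carbon, brings no aryl compound back to a measured number, and no compound here goes against this. The steps from compound 3 to compound 4 and from compound 2 to compound 4 still cannot be read, because each of these compounds has only a limit and not a number: the limit of > 10000 nM in this assay, at which 3 of the 4 values shown sit.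

On these data alone, how far compound 2, compound 3 and compound 4 lie past that limit stays unknown, so no order can be given among them. Also open, as far as these compounds go, is whether a plain benzyl group with no fluorine, a longer saturated carbon chain, or a chain ending in an amine in this same place would give a measured number in this assay and how it would compare with compound 1.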